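A few compounds are considered here, and "the series" means these few. Any claim that something is new, unique, unknown or untested is made for them only; others in the source may bear on it.

Compound 1 `CCOC(=O)c1ccc(NC(=O)N2CC2C#N)cc1` carries the cyanoaziridine urea core shared by the set, with an aryl urea bearing ethoxycarbonyl. For the measured compounds named here, in a functional assay on WiDr cells (Homo sapiens) for inhibition (on this read-out lower numbers stand for stronger inhibition and higher numbers for weaker inhibition), compound 1 gives 4200 nM, the lowest of the three numbers so far. Compound 2 `CCCCNC(=O)N1CC1C#N`, in which the aromatic ring is replaced by a butyl chain, gives in this assay 18000 nM, and compound 3 `N#CC1CN1C(=O)Nc1cccnc1`, with a pyridyl in place of the substituted phenyl, gives 18000 nM; both sit well beyond the scatter from compound 1, so the substituted phenyl urea is the best-placed arrangement among these three.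

Compound 4 `N#CC1CN1C(=O)Nc1ccc(C(F)(F)F)cc1` is the next point in the aryl series. Relative to compound 1 the change is trifluoromethyl in place of ethoxycarbonyl on an aromatic carbon. No pair of measured compounds yet covers a swap of one aromatic substituent for another at this position, so the direction of the step in this assay is not anchored by a shown step. On the numbers alone, a small step is expected, either way, within or near the scatter, with a modest chance of weakening. For compound 4 the estimate is 5500 nM (range 1500 nM to 18000 nM), a step from compound 1 to compound 4 of a 1.3-fold higher number from compound 1 to compound 4 (0.12 log units; within the scatter) expected.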

Compound 4, half-maximal inhibitory concentration: 5800 nM
Estimate against measurement, compound 4: 1.1-fold (0.02 log units) below; the measured number falls inside the stated range.
By their numbers in this assay, from the lowest: compounds 1 and 4 (each within the scatter of the next); then compounds 2 and 3 (each within the scatter of the next).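

In this assay, for the compounds shown here, trifluoromethyl in place of ethoxycarbonyl on an aromatic carbon gives a 1.4-fold higher number from compound 1 to compound 4 (0.14 log units; within the scatter) and is the first step that can be read at this position. The group entering has 0 hydrogen-bond acceptors against 2 for the group leaving, and no double bond against 1, yet the read-out does not separate the two, so this one pair gives no sign that either feature of ethoxycarbonyl is needed here. No measured evidence bears on why the two groups read alike.

On these data alone, what an amine, a carboxylic acid or a plain hydrogen would give at this carbon remains open. Also open, as far as these compounds go, is whether the same exchange reads alike on another carbon of the ring.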